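Dropping the Methoxy Group from a Small Azido Coumarin

The source may hold more compounds than are shown below. What is called first, only, known or untested is meant among the compounds shown, and "the series" means these compounds.

Of the compounds shown here, two have been measured in a functional assay on HeLa cells (Homo sapiens) for cytotoxicity, read by MTT assay, with a stated time of 24 h; a higher number here means a weaker inhibitor, a lower number a stronger inhibitor. Compound 1 `COc1cccc2cc(N=[N+]=[N-])c(=O)oc12` gives 36400 nM in this assay. Compound 2 `NCCC(=O)N1Cc2ccccc2-c2nnn(-c3cc4cc(Br)ccc4oc3=O)c2-c2ccccc21` gives 18200 nM in this assay, and the gap between compound 2 and compound 1 lies within the usual scatter of repeated measurements, so the two numbers cannot be told apart. Compound 3 `[N-]=[N+]=Nc1cc2ccccc2oc1=O` has not been measured yet. It differs from compound 1 in one place: hydrogen in place of methoxy on an aromatic carbon. Going by the values given here, no measured pair shows what such a change does here, and compound 2 differs from compound 1 in far too many places to serve as a guide. Among the compounds with values here, with nothing to rest on beyond the single number for compound 1, the change is expected to produce no step beyond the scatter in either direction. Compound 3 is therefore expected to give 40000 nM in this assay, with a likely range from 15000 nM to 110000 nM. That estimate means an expected step of a 1.1-fold higher number from compound 1 to compound 3 (0.04 log units; within the scatter).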

Compound 3, half-maximal inhibitory concentration: 29600 nM
Compound 3: middle estimate off by 1.4-fold (0.13 log units), on the high side; the measured number falls inside the stated range.
By their numbers in this assay, from the lowest: compounds 2, 3 and 1 (each within the scatter of the next).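

Going by these compounds alone, this is the first measured pair that isolates a single change: with hydrogen in place of methoxy on an aromatic carbon, this assay shows a 1.2-fold lower number from compound 1 to compound 3 (0.09 log units; within the scatter) and so leaves compound 1 and compound 3 indistinguishable. For this one pair, the methoxy group is therefore not needed to keep the cytotoxicity seen with compound 1, and removing it costs nothing measurable. Nothing available here helps to explain this outcome.

On these data alone, whether any other group at this position, such as an amine, a carboxylic acid or a longer ether chain like butoxy, would move the number beyond the scatter remains open. One pair also cannot show whether the same swap would behave alike on a different core.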